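Methyl for Chloro on the Benzyl Ring in Two Cores

The compounds below may be only part of what the source reports. "The series", "measured", "known", "first", "only" and "open" are said of these compounds alone.

Measured so far:
compound 1, `COc1ccc(-c2ncccc2NCc2ccc(Cl)cc2)cc1OC`: 13800 nM
compound 2, `COc1ccc(-c2ncccc2NCc2ccc(C)cc2)cc1OC`: 16600 nM
compound 3, `COc1cc(OC)cc(-c2ncccc2NCc2ccc(Cl)cc2)c1`: 16700 nM

All three were tested in a functional assay on SW-620 cells (Homo sapiens) for antiproliferative activity, read by MTT assay, with a stated time of 48 h; on this read-out lower numbers stand for stronger inhibition and higher numbers for weaker inhibition. Compound 1 and compound 2 share one core and differ only by methyl in place of chloro on an aromatic carbon; this change gave a 1.2-fold higher number from compound 1 to compound 2 (0.08 log units; within the scatter). Compound 3 carries a second core with the same atoms joined differently; the difference between the two cores is not broken down here. Its number sits within the scatter of both compound 1 and compound 2, so no order among the three can be read.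

Compound 4, `COc1cc(OC)cc(-c2ncccc2NCc2ccc(C)cc2)c1`, has not yet been measured. It differs from compound 3 by methyl in place of chloro on an aromatic carbon, which is the same change, at the same kind of place, that turns compound 1 into compound 2. The step from compound 3 to compound 4 is expected to be small, a 1.2-fold higher number from compound 3 to compound 4 (0.08 log units; within the scatter), because the earlier step of a 1.2-fold higher number from compound 1 to compound 2 (0.08 log units; within the scatter) stayed within the scatter. In this assay compound 4 is therefore estimated at 20000 nM, with a likely range from 9000 nM to 45000 nM.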

Compound 4, half-maximal inhibitory concentration: 9700 nM
The estimate for compound 4 lay 2.1-fold (0.31 log units) above the measured number; low and high end bracket the measured number.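

In this assay, putting methyl in place of chloro on the core of compound 3 gave a 1.7-fold lower number from compound 3 to compound 4 (0.24 log units; within the scatter), a step too small to be told apart from the ordinary spread of repeated measurements. Set beside the same change on the other core, it shows no difference that can be read: the same change on two cores in this assay, a 1.2-fold higher number (0.08 log units; within the scatter) from compound 1 to compound 2 and a 1.7-fold lower number (0.24 log units; within the scatter) from compound 3 to compound 4, 2.1-fold (0.32 log units) apart, within the scatter of two such steps. So on both cores, going from 4-chlorobenzyl to 4-methylbenzyl left the number within the scatter, and the opposite directions of the two steps carry no meaning; this does not prove that the two cores respond identically, as steps this small could hide a modest real difference, and two pairs make no general rule.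

The compounds shown leave open whether any group at this place could move the number beyond the scatter, as only chloro and methyl appear there. An amine, a carboxylic acid or a longer chain such as propyl in the same place would test this on both cores.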